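This account rests on a few compounds, and the source may have more. Where it says the series, first, only, none or still open, it means among the compounds named here.

Three measured compounds share one core. Compound 1 `C=CC(=O)Nc1cccc(NC(=O)CSc2nc(Nc3ccccc3Br)c3ccccc3n2)c1` gives 12800 nM in a functional assay on MGC-803 cells (Homo sapiens) for inhibition, read by MTT assay, with a stated time of 72 h; on this read-out lower numbers stand for stronger inhibition and higher numbers for weaker inhibition. Compound 2 `C=CC(=O)Nc1cccc(NC(=O)CSc2nc(Nc3ccccc3C)c3ccccc3n2)c1` gives 30200 nM in this assay, and the step of a 2.4-fold higher number from compound 1 to compound 2 (0.37 log units; beyond the scatter) is the only one beyond the scatter among the three. Compound 3 `C=CC(=O)Nc1cccc(NC(=O)CSc2nc(Nc3ccc(C(F)(F)F)cc3)c3ccccc3n2)c1` gives 12100 nM in this assay, the lowest of the three numbers; its step from compound 1, a 1.1-fold lower number from compound 1 to compound 3 (0.02 log units; within the scatter), lies within the scatter, while the step of a 2.5-fold lower number from compound 2 to compound 3 (0.40 log units; beyond the scatter) is modest and beyond it.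

Compound 4 `C=CC(=O)Nc1cccc(NC(=O)CSc2nc(Nc3ccc(Cl)c(Cl)c3)c3ccccc3n2)c1` is not yet measured. It differs from compound 3 by 3,4-dichlorophenyl in place of 4-(trifluoromethyl)phenyl on a nitrogen on an aromatic ring. Going by the values given here, only the step of a 2.5-fold lower number from compound 2 to compound 3 (0.40 log units; beyond the scatter) and the step of a 1.1-fold lower number from compound 1 to compound 3 (0.02 log units; within the scatter) bear on an aryl exchange at this nitrogen, and they show numbers within or only modestly outside the scatter. Among the compounds with values here, no step from compound 3 to compound 4 beyond the scatter is therefore expected; the estimated step is a 1.0-fold lower number from compound 3 to compound 4 (0.00 log units; within the scatter). Compound 4 is expected to give about 12000 nM in this assay, within a range of 5000 nM to 30000 nM.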

Compound 4, half-maximal inhibitory concentration: > 50000 nM
Compound 4: no number, only a limit (the forecaster's own chance of this, stated with the estimate: 5%); at least 4.1-fold (0.61 log units) between middle value and limit.
By their numbers in this assay, from the lowest: compounds 3 and 1 (each within the scatter of the next); then compound 2. At a limit, above all of these: compound 4.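

In this assay compound 4 gives > 50000 nM, which is a limit and not a number. The aryl group on this nitrogen is not freely exchangeable, as the earlier exchanges alone might have suggested: 3,4-dichlorophenyl weakens inhibition in an at least 4.1-fold higher number from compound 3 to compound 4 (0.61 log units; beyond the scatter) and in an at least 3.9-fold higher number from compound 1 to compound 4 (0.59 log units; beyond the scatter), both beyond the scatter. The remaining step, an at least 1.6-fold higher number from compound 2 to compound 4 (0.21 log units; that floor lies within the scatter), has only a floor, so the order of that pair cannot be read.

The compounds shown do not tell whether the loss needs both chlorines or would already appear with a single chlorine, as in 4-chlorophenyl. From the compounds shown here alone, how an aryl group carrying an amine or a carboxylic acid would read at this nitrogen also remains open.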